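Oxazole to thiazole at the amide-type ring nitrogen

A few compounds are considered here, and "the series" means these few. Any claim that something is new, unique, unknown or untested is made for them only; others in the source may bear on it.

Values in a functional assay on U-266 cells (Homo sapiens) for inhibition, read by MTT assay, with a stated time of 48 h, tested at 0.1 uM (a higher number here means more inhibition at the concentration tested (going by the name of the read-out), a lower number less inhibition), for the measured compounds:
compound 1 `Cc1noc(C)c1-c1ccc2c(c1)C(c1ccccc1)NC(=O)N2C` gives 13.1%
compound 2 `Cc1noc(C)c1-c1ccc2c(c1)C(c1ccccc1)N(Cc1ncc(-c3ccccc3)o1)C(=O)N2C` gives 15.1%
compound 3 `Cc1noc(C)c1-c1ccc2c(c1)C(c1ccccc1)N(Cc1nnc(-c3ccccc3)s1)C(=O)N2C` gives 20.3%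

Compound 2 stands second highest of the three numbers. Its nearest neighbour is compound 1, with a number 2 percentage points higher from compound 1 to compound 2 (within the scatter); its furthest is compound 3, with a number 5.2 percentage points higher from compound 2 to compound 3 (within the scatter). All three values lie within the scatter of one another, so no order among them can be read.

Compound 4 `Cc1noc(C)c1-c1ccc2c(c1)C(c1ccccc1)N(Cc1nc(-c3ccccc3)cs1)C(=O)N2C` is not yet measured. It differs from compound 2 by 4-phenyl-1,3-thiazol-2-yl in place of 5-phenyl-1,3-oxazol-2-yl on a saturated chain carbon bound to an amide-type nitrogen in a ring.

The step that bears most directly on this change is a number 5.2 percentage points higher from compound 2 to compound 3 (within the scatter), an exchange of one five-membered ring for another at the same place, which stayed within the scatter. The steps of a number 2 percentage points higher from compound 1 to compound 2 (within the scatter) and a number 7.2 percentage points higher from compound 1 to compound 3 (within the scatter) show that adding the whole side group on the amide-type nitrogen also moved the number only within the scatter. On this basis compound 4 is expected to show a number 1.9 percentage points higher from compound 2 to compound 4 (within the scatter), that is, no step beyond the scatter. The estimate for compound 4 in this assay is 17%, with a range from 8% to 28%.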

Compound 4, a percentage reported as inhibition, at one concentration (the size of the read-out at that concentration, not a potency): 12.7%
Compound 4: middle estimate off by 4.3 percentage points, on the high side; the range from low to high includes it.
By their numbers in this assay, from the lowest: compounds 4, 1, 2 and 3 (each within the scatter of the next).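

In this assay, a third five-membered aromatic ring at the saturated chain carbon bound to an amide-type nitrogen in a ring, 4-phenyl-1,3-thiazol-2-yl, stays within the scatter of both earlier rings (a number 2.4 percentage points lower from compound 2 to compound 4 (within the scatter); a number 7.6 percentage points lower from compound 3 to compound 4 (within the scatter)). The (4-phenyl-1,3-thiazol-2-yl)methyl group in place of hydrogen on the amide-type nitrogen likewise stays within the scatter (a number 0.4 percentage points lower from compound 1 to compound 4 (within the scatter)), so no group shown at this position separates from the unsubstituted compound 1. No supporting measurement bears on these numbers.

Open, as far as these compounds go, is whether any other group here gives a step beyond the scatter, for example a dimethylamino group, a carboxylic acid or a longer chain carrying the ring. Also open, from the compounds shown here alone, is how these compounds compare at other concentrations in this assay.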